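A few compounds are considered here, and "the series" means these few. Any claim that something is new, unique, unknown or untested is made for them only; others in the source may bear on it.

The measured compounds:
compound 1, `CC(C)NC(=N)NC1=NC(=O)CN1c1cccc(Cl)c1Cl`; in an in vivo ADME assay on the whole organism for metabolic stability, with Homo sapiens as the target, read by LC-MS, at a dose of 320 mg/kg by the oral route (a higher number here means that the compound lasts longer, a lower number that the compound disappears faster), compound 1 gives 0.896 h.
compound 2, `CC(C)/N=C(\NC1=NC(=O)CN1C(C)C)Nc1ccc(Cl)c(Cl)c1`; in this assay compound 2 gives 0.883 h.

Compound 2 stands as the lower of the two numbers shown, though its only neighbour, compound 1, lies within the usual scatter of it, so the two half-lives cannot be told apart. Compound 3, `CCOC(=O)/N=C(\NC1=NC(=O)CN1C(C)C)Nc1ccc(Cl)c(Cl)c1`, has not yet been measured in this assay. It differs from compound 2 in one place: ethoxycarbonyl in place of isopropyl on a double-bonded nitrogen. Among the compounds with values here, no step between measured compounds bears on this change, and the two measured values give no direction to read from. The account therefore expects the step from compound 2 to compound 3 to stay within the scatter, with a 1.1-fold lower number from compound 2 to compound 3 (0.04 log units; within the scatter) as the expected size. For compound 3 the estimated half-life is 0.8 h, in an expected range from 0.4 h to 1.6 h.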

Compound 3, half-life: 0.572 h
For compound 3 the middle estimate is 1.4-fold (0.15 log units) above the measured one; measured number inside the range.
By their numbers in this assay, from the lowest: compounds 3, 2 and 1 (each within the scatter of the next).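

In this assay, within the data shown here, the exchange of isopropyl for ethoxycarbonyl on a double-bonded nitrogen gives the first step that can be read at this position, and it shows a 1.5-fold lower number from compound 2 to compound 3 (0.19 log units; within the scatter). The position therefore accepts a group with more heavy atoms, two oxygens and hydrogen-bond acceptors where isopropyl has none, and the half-life stays within the scatter of compound 2. Nothing available here accounts for the direction of the printed difference or gives it a cause.

The compounds shown leave open whether an amine, a carboxylic acid or a longer chain on this nitrogen would move the half-life beyond the scatter. With a single step at this position, they also establish no trend for the groups placed there.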